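The compounds below may be only part of what the source reports. "The series", "measured", "known", "first", "only" and "open" are said of these compounds alone.

Compound 1 `C=CC(C)(O)CC[C@@H]1C(=C)CC[C@H](Br)[C@@]1(C)CCC(Br)C(C)(C)O`: > 100000 nM; 66300 nM (2 entries)
Compound 2 `C=CC(C)(O)CC[C@@H]1C(=C)CC[C@H](Br)[C@@]1(C)CCC(O)C(C)(C)O`: > 100000 nM, a limit of the assay
Compound 3 `C=CC(C)(O)CC[C@@H]1C(=C)CC[C@H](Br)[C@@]1(C)CCC(OC)C(C)(C)O`: > 100000 nM, a limit of the assay

The test here is a functional assay on HepG2 cells (Homo sapiens) for cytotoxicity, read by MTT assay, with a stated time of 48 h; a higher number here means a weaker inhibitor, a lower number a stronger inhibitor. In this assay compound 3 gives > 100000 nM, which is a limit and not a number.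

The next molecule is compound 4 `C=CC(C)(O)CC[C@@H]1C(=C)CC[C@H](Br)[C@@]1(C)CCC(=O)C(C)C`. The change is isopropylcarbonyl in place of 2-hydroxy-1-methoxy-2-methylpropyl on a saturated chain carbon, two bonds along the chain from a saturated ring carbon.

Within the data shown here, only one measured step lies close to this change, a step that the two limits leave unreadable from compound 2 to compound 3, and it gives no size to carry over. The remaining guidance comes from the limit of > 100000 nM in this assay, at which 2 of the 3 values shown sit, and from the several entries of compound 1 in this assay, > 100000 nM; 66300 nM (2 entries). With no readable step to build on, no step beyond the usual scatter is expected in this assay, and no direction can be given. Compound 4 is therefore expected to stay as weak as the others, and a bare limit is a likely result. The expected step is a number no higher from compound 3 to compound 4 (the limit leaves the size open). The estimate for compound 4 is 100000 nM, with an expected range of 50000 nM to 200000 nM.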

Compound 4, half-maximal inhibitory concentration: > 100000 nM
Compound 4 ended at the assay's limit; the forecaster's own chance of this, stated with the estimate: 70%; the middle value sits exactly at the limit.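

In this assay compound 4 gives > 100000 nM, which is a limit and not a number. Among these compounds, compound 2, compound 3 and compound 4 all stand only as limits, so no step among them can be read. Going by these compounds, whether these chain changes alter strength in this assay stays open.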